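The source may hold more compounds than are shown below. What is called first, only, known or untested is meant among the compounds shown, and "the series" means these compounds.

Measured compounds and their values:

Compound 1, `C[C@@H](NC(=O)Nc1cccc(F)c1)c1ccccc1`, in an ADME assay on the whole organism with Oryza sativa as the target, tested at 10 uM; a higher number here means a weaker effect of the compound at the concentration tested, a lower number a stronger effect: 84%
Compound 2, `C[C@H](NC(=O)Nc1ccc(F)cc1)c1ccccc1`, in this assay: 85%
Compound 3, `C[C@H](NC(=O)Nc1ccc(F)c(F)c1)c1ccccc1`, in this assay: 98%

Compounds 1 and 2 are built from the same atoms joined differently; the difference between the two cores is not broken down here. Their values in this assay lie within the scatter of each other, so nothing separates them.

From compound 2 to compound 3 the change is fluoro in place of hydrogen on an aromatic carbon. This single change gives a step of a number 13 percentage points higher from compound 2 to compound 3 (beyond the scatter), which lies beyond the scatter and points toward a weaker effect.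

Compound 4, `C[C@@H](NC(=O)Nc1cc(F)cc(F)c1)c1ccccc1`, has not yet been measured. It differs from compound 1 by fluoro in place of hydrogen on an aromatic carbon. Among the measured compounds shown here, this is the same kind of change as the one from compound 2 to compound 3, but not the same: in compound 3 the entering fluoro sits ortho to a fluoro group, while in compound 4 it sits meta to a fluoro group; in both it is meta to a large group.

For the measured compounds named here, with only one example of this change measured, the expectation for compound 4 rests on that single step. Compound 4 is expected to move by about a number 11 percentage points higher from compound 1 to compound 4 (beyond the scatter) in this assay, because compound 3 showed a number 13 percentage points higher from compound 2 to compound 3 (beyond the scatter) from the same kind of change. For compound 4 the value in this assay is therefore estimated at 95%, with a range from 84% to 100%.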

Compound 4, a percentage reported as activity, at one concentration (the size of the read-out at that concentration, not a potency): 96%
Compound 4: middle estimate off by 1 percentage points, on the low side; measured number inside the range.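

In this assay, placing a second fluoro on the aromatic ring of compound 1 gives a number 12 percentage points higher from compound 1 to compound 4 (beyond the scatter), which points toward a weaker effect at the concentration tested, and this step closely matches the one seen earlier on the other core: the same change on two cores in this assay, a number 13 percentage points higher (beyond the scatter) from compound 2 to compound 3 and a number 12 percentage points higher (beyond the scatter) from compound 1 to compound 4, 1 percentage points apart, within the scatter of two such steps. Within this small set, then, the change carries over from one core to the other, with the same direction and a similar size each time. Among the compounds shown here, this rests on only two pairs, however, both of which already carry a fluoro on the ring that receives the new one, so it does not show why the number rises or whether the same step would appear on a core without that first fluoro.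

The compounds shown have only fluoro as a substituent on this aromatic ring, so it remains open whether a chloro, a methoxy or an amine at the same kind of place would shift the number in the same way. Going by these compounds, it also remains open how a compound with no fluoro at all would read, which would show what the first fluoro contributes on its own.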